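Carboxyl position on the aryl ether of compound 3

The source may hold more compounds than are shown below. What is called first, only, known or untested is meant among the compounds shown, and "the series" means these compounds.

Measured so far in a functional assay on HEK293 cells for agonist activity at Bile acid receptor (Homo sapiens); on this read-out lower numbers stand for an effect already at smaller amounts and higher numbers for an effect only at larger amounts of compound:
compound 1, `CC(Nc1ccc(C(=O)O)cc1)c1ccc(OCc2c(-c3c(Cl)cccc3Cl)noc2C2CC2)nc1C(F)(F)F`, gives 333 nM
compound 2, `O=C(O)c1cccc(OCc2ccc(OCc3c(-c4c(Cl)cccc4Cl)noc3C3CC3)nc2C(F)(F)F)c1`, gives 151 nM
compound 3, `CC(Oc1cccc(C(=O)O)c1)c1ccc(OCc2c(-c3c(Cl)cccc3Cl)noc2C2CC2)nc1C(F)(F)F`, gives 107 nM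

Compound 3 shows the lowest number of the three; against compound 2 the gap is a 1.4-fold lower number from compound 2 to compound 3 (0.15 log units; within the scatter), within the scatter, so no order between those two can be claimed, while against compound 1 the gap is a 3.1-fold lower number from compound 1 to compound 3 (0.49 log units; beyond the scatter), beyond the scatter.

Compound 4, `CC(Oc1ccc(C(=O)O)cc1)c1ccc(OCc2c(-c3c(Cl)cccc3Cl)noc2C2CC2)nc1C(F)(F)F`, differs from compound 3 only in the position of the acid: 4-carboxyphenyl in place of 3-carboxyphenyl on an oxygen on a saturated carbon. Within the data shown here, no measured step changes the carboxyl position alone. The steps of a 2.2-fold lower number from compound 1 to compound 2 (0.34 log units; beyond the scatter) and a 3.1-fold lower number from compound 1 to compound 3 (0.49 log units; beyond the scatter) each move the acid from the 4- to the 3-position, but both also exchange the amine link for an ether. The acid position on its own has not been varied among the measured compounds. Both steps were modest. The reverse move in compound 4 is therefore expected to give a modest shift toward a higher number at most, a 1.9-fold higher number from compound 3 to compound 4 (0.27 log units; within the scatter), possibly none beyond the scatter. Compound 4 is estimated at 200 nM, within 80 nM to 500 nM.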

Compound 4, half-maximal effective concentration: 189 nM
Compound 4: middle estimate off by 1.1-fold (0.02 log units), on the high side; measured number inside the range.
By their numbers in this assay, from the lowest: compounds 3, 2, 4 and 1 (each within the scatter of the next, the first and the last beyond it).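

In this assay, among these compounds, the change of 4-carboxyphenyl for 3-carboxyphenyl on the oxygen gives the first step that alters the acid position alone (a 1.8-fold higher number from compound 3 to compound 4 (0.25 log units; within the scatter)), and it stays within the scatter, so no effect of the acid position can be claimed at this site. With the acid position held at 4-carboxyphenyl, the exchange of the amine link for the ether also stays within the scatter (a 1.8-fold lower number from compound 1 to compound 4 (0.25 log units; within the scatter)), so neither change alone reproduces the gap beyond the scatter between compound 1 and compound 3. Removing the methyl from the link while also moving the acid gives a step that is likewise within the scatter (a 1.3-fold higher number from compound 2 to compound 4 (0.10 log units; within the scatter)).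

Still open, as far as these compounds go, is whether a tetrazole or an amide in place of the carboxylic acid would retain the effect in this assay. No available evidence bears on the reason for these small steps.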